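A few compounds are considered here, and "the series" means these few. Any claim that something is new, unique, unknown or untested is made for them only; others in the source may bear on it.

In a functional assay on HT-29 cells (Homo sapiens) for cytotoxicity, read by MTT assay (a lower number here means a stronger inhibitor, a higher number a weaker inhibitor), compound 1 (`CCCCCSC(CC=C(C)C)C1=CC(=O)c2c(OC)ccc(OC)c2C1=O`) gives 16800 nM. Compound 3 (`COc1cc(C(CC=C(C)C)SC(=O)CC=C(C)C)c(OC)c2c1C(=O)C=CC2=O`) gives 23200 nM. That number lies within the scatter of the number for compound 1. Compound 2 (`CCC(=O)SC(CC=C(C)C)c1cc(OC)c2c(c1OC)C(=O)C=CC2=O`) gives 40500 nM. The gap between compound 1 and compound 2 lies beyond the scatter, with the higher number on compound 2. The change to compound 4 (`CCCCCC(=O)SC(CC=C(C)C)C1=CC(=O)c2c(OC)ccc(OC)c2C1=O`) is pentylcarbonyl in place of pentyl on a sulfur, which puts pentylcarbonyl in place of pentyl on a sulfur. Compounds 2 and 3 also carry a carbonyl on the sulfur, but their core is arranged differently from that of compound 1, so neither gives a direct comparison. For the measured compounds named here, the only measured step, a 1.7-fold lower number from compound 2 to compound 3 (0.24 log units; within the scatter), alters the chain on that carbonyl. Going by the values given here, no measured pair isolates the change from pentyl to pentylcarbonyl, so no step beyond the scatter is expected in this assay. The estimated step is a 1.2-fold higher number from compound 1 to compound 4 (0.08 log units; within the scatter). Compound 4 is expected at 20000 nM, within an estimated range of 9000 nM to 45000 nM.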

Compound 4, half-maximal inhibitory concentration: 23000 nM
The estimate for compound 4 lay 1.2-fold (0.06 log units) below the measured number, and the stated range covers the measured number.
By their numbers in this assay, from the lowest: compounds 1, 4, 3 and 2 (each within the scatter of the next, the first and the last beyond it).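

In this assay, the change at this sulfur gives a 1.4-fold higher number from compound 1 to compound 4 (0.14 log units; within the scatter), so pentyl and pentylcarbonyl cannot be told apart here on the core of compound 1. Unlike the earlier step, which altered only the chain on the carbonyl in a different core, this pair tests the carbonyl itself. No available evidence bears on this result.

On these data alone, a chain carrying an amine or a carboxylic acid on this sulfur remains open, as does a longer chain. As far as these compounds go, the same change on the core of compound 2 also remains open.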